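Chloro to Hydroxy on the Aryl Ring, Paw Edema

The source may hold more compounds than are shown below. What is called first, only, known or untested is meant among the compounds shown, and "the series" means these compounds.

Of the compounds shown here, three have been measured in a functional assay on the whole organism (strain Wistar) for inhibition, with Rattus norvegicus as the target, read by paw edema, with a stated time of 30 min, at a dose of 10 mg/kg by the intraperitoneal route; a lower number here means less inhibition, a higher number more inhibition at the dose given (going by the name of the read-out). Compound 1 `O=C(N/N=C/c1ccccc1)c1cccnc1Nc1cccc(C(F)(F)F)c1` gives 60.4%. Compound 2 `O=C(N/N=C/c1cccc(Cl)c1)c1cccnc1Nc1cccc(C(F)(F)F)c1` gives 77.8%. Compound 3 `O=C(N/N=C/c1ccc(Cl)cc1)c1cccnc1Nc1cccc(C(F)(F)F)c1` gives 52.4%.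

Within the data shown here, compound 3 stands lowest of the three numbers, but its distance from compound 1 is within the scatter, so the two cannot be ordered; only the step of a number 25.4 percentage points lower from compound 2 to compound 3 (beyond the scatter) lies beyond the scatter. Compound 4 `O=C(N/N=C/c1ccc(O)cc1)c1cccnc1Nc1cccc(C(F)(F)F)c1` is the next compound in this assay, and it differs from compound 3 by hydroxy in place of chloro on an aromatic carbon.

Among the measured compounds shown here, no measured step swaps chloro for hydroxy, so the expectation must rest on neighbouring steps. The step of a number 8 percentage points lower from compound 1 to compound 3 (within the scatter) shows that putting chloro onto this aromatic carbon, or taking it away, moves the number only within the scatter. The step of a number 17.4 percentage points higher from compound 1 to compound 2 (beyond the scatter) shows that chloro on a different aromatic carbon gave a modest rise, which says nothing direct about the carbon changed here. With so little leverage from the data, the step of a number 3.6 percentage points higher from compound 3 to compound 4 (within the scatter) is expected to stay within the scatter, with a slight lean upward toward the value of compound 1. Compound 4 is therefore estimated to give 56%, with a range from 40% to 72%.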

Compound 4, a percentage reported as inhibition, in the whole organism at one dose (the size of the read-out at that dose, not a potency): 59.3%
Compound 4: middle estimate off by 3.3 percentage points, on the low side; the range from low to high includes it.
By their numbers in this assay, from the lowest: compounds 3, 4 and 1 (each within the scatter of the next); then compound 2.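

In this assay, the swap of 4-chlorophenyl to 4-hydroxyphenyl comes out as a number 6.9 percentage points higher from compound 3 to compound 4 (within the scatter) and hydroxy in place of hydrogen on the same aromatic carbon as a number 1.1 percentage points lower from compound 1 to compound 4 (within the scatter) and so, on this carbon para to a large group, hydrogen, chloro and hydroxy cannot be told apart. Earlier, only hydrogen and chloro could be compared here; now a group that brings a hydrogen-bond donor and a hydrogen-bond acceptor, where chloro brings neither, also gives a number that cannot be separated from the other two. Moving from the 3-chlorophenyl of compound 2 to this new group gives a number 18.5 percentage points lower from compound 2 to compound 4 (beyond the scatter) and, with its steps to compound 1 and compound 3 also beyond the scatter, compound 2 remains the only one of the four that stands apart.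

Nothing available here explains why these three groups read alike or why compound 2 stands apart. From the compounds shown here alone, whether a methoxy group, an amine or a carboxylic acid on this carbon would also read like hydrogen remains open, as does what hydroxy would do on the aromatic carbon that carries chloro in compound 2.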